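This account rests on a few compounds, and the source may have more. Where it says the series, first, only, none or still open, it means among the compounds named here.

Measured so far:
compound 1, `Cc1cc(C)c(Oc2cc(Nc3ccc(C#N)cc3)ncc2C(=O)NCc2cn(Cc3ccccc3[N+](=O)[O-])nn2)c(C)c1`: > 212000 nM
compound 2, `Cc1cc(C)c(Oc2cc(Nc3ccc(C#N)cc3)ncc2C(=O)NCc2cn(CC(N)=O)nn2)c(C)c1`: 24000 nM
compound 3, `Cc1cc(C)c(Oc2cc(Nc3ccc(C#N)cc3)ncc2C(=O)NCc2cn(Cc3cccc(F)c3)nn2)c(C)c1`: >= 204000 nM

In an ADME assay on MT4 cells (Homo sapiens) for cytotoxicity, read by MTT assay, with a stated time of 5 days (a higher number here means that more compound is tolerated, a lower number that less compound is tolerated), compound 1 gives > 212000 nM, which is a limit of the assay and not a number. Compound 2 gives 24000 nM. Compound 3 gives >= 204000 nM, also a limit. Compound 4, `Cc1cc(C)c(Oc2cc(Nc3ccc(C#N)cc3)ncc2C(=O)NCc2cn(CCC#N)nn2)c(C)c1`, has not been measured in this assay; it differs from compound 1 in one place: cyanomethyl in place of 2-nitrophenyl on a saturated chain carbon bound to an aromatic nitrogen. The step that bears on it most closely is an at least 8.8-fold lower number from compound 1 to compound 2 (0.94 log units; beyond the scatter), where a different group replaces the same 2-nitrophenyl. The step that the two limits leave unreadable from compound 1 to compound 3 adds nothing readable. A lower number is therefore expected for compound 4, and the expected step is an at least 5.3-fold lower number from compound 1 to compound 4 (0.72 log units; beyond the scatter). Compound 4 is estimated at 40000 nM, with a range from 15000 nM to 150000 nM.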

Compound 4, half-maximal cytotoxic concentration: 40200 nM
Beside the measured number, compound 4's estimate is 1.0-fold (0.00 log units) below it; the measured number falls inside the stated range.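

In this assay the ringless cyanomethyl group matches the ringless carbamoyl group, with a 1.7-fold higher number from compound 2 to compound 4 (0.22 log units; within the scatter) being no real difference. Against the two groups that carry a phenyl ring, the picture changes: an at least 5.2-fold lower number from compound 1 to compound 4 (0.72 log units; beyond the scatter) and an at least 5.0-fold lower number from compound 3 to compound 4 (0.70 log units; beyond the scatter) both lie beyond the scatter. Among these four compounds the split follows the phenyl ring on the chain, and none goes against it.

From the compounds shown here alone, compound 1 and compound 3 are limits and not numbers, so how far those two steps truly reach stays open. A longer carbon chain without a ring, or an amine, could show whether the ring itself or simply the size of the group goes with the split.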